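The compounds below may be only part of what the source reports. "The series", "measured", "known", "first", "only" and "open" are said of these compounds alone.

Three compounds share one core and differ only in the groups hung on its two outer rings. Compound 1 `O=C1CSC(N2N=C(c3ccc(Cl)c(Cl)c3)CC2c2ccccc2)=N1` carries a plain phenyl ring and a 3,4-dichlorophenyl ring; in an ADME assay on RAW264.7 cells (Mus musculus) for cytotoxicity, read by MTT assay, with a stated time of 24 h (on this read-out lower numbers stand for higher toxicity in this test and higher numbers for lower toxicity in this test), compound 1 gives 295000 nM. Compound 2 `O=C1CSC(N2N=C(c3ccc(Cl)c(Cl)c3)CC2c2ccc(Cl)cc2)=N1` adds a chloro group to the phenyl ring, and in this assay compound 2 gives 187000 nM; the change is a 1.6-fold lower number from compound 1 to compound 2 (0.20 log units; within the scatter). Compound 3 `Cc1ccc(C2=NN(C3=NC(=O)CS3)C(c3ccccc3)C2)cc1C` instead swaps the 3,4-dichlorophenyl ring for a 3,4-dimethylphenyl ring. In this assay compound 3 gives > 450000 nM, which is a limit of the assay and not a number; it stands at the limit of > 450000 nM in this assay, at which 1 of the 3 values shown sits. The step is an at least 1.5-fold higher number from compound 1 to compound 3 (0.18 log units; that floor lies within the scatter), so on the numbers shown compound 3 sits at the least toxic end, though that floor alone does not separate it from compound 1.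

Compound 4 `Cc1cccc(C2CC(c3ccc(C)c(C)c3)=NN2C2=NC(=O)CS2)c1` is the next step, differing from compound 3 by methyl in place of hydrogen on an aromatic carbon. The two measured steps bear on it, both small ring substitutions and both within the scatter, so the step of a number no higher from compound 3 to compound 4 (the limit leaves the size open) is expected to stay within the scatter as well. Compound 4 is therefore expected to give about 450000 nM, somewhere between 250000 nM and 900000 nM, most likely again as a limit.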

Compound 4, half-maximal cytotoxic concentration: 237000 nM
Compound 4: the middle estimate sits 1.9-fold (0.28 log units) above what was measured; the whole stated range lies above it.
By their numbers in this assay, from the lowest: compounds 2, 4 and 1 (each within the scatter of the next). At a limit, above all of these: compound 3.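

Among these compounds, compound 4 shows a methyl group on the plain phenyl ring with the 3,4-dimethylphenyl ring in place, a change from phenyl to 3-methylphenyl that the earlier compounds did not cover. The step in this assay reads an at least 1.8-fold lower number from compound 3 to compound 4 (0.27 log units; that floor lies within the scatter) and replaces a limit with a number that can be compared directly. From the compounds shown here alone, its true size stays open, because the value of compound 3 is a limit and not a number: the limit of > 450000 nM in this assay, at which 1 of the 4 values shown sits.

The compounds shown leave open how the number would move with an amine, a carboxylic acid or a longer chain in place of this methyl. They also leave open whether the same methyl would give a comparable step with the 3,4-dichlorophenyl ring in place of the 3,4-dimethylphenyl ring.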